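Azole replacement of the methylpyridyl group in compound 1

The source may hold more compounds than are shown below. What is called first, only, known or untested is meant among the compounds shown, and "the series" means these compounds.

For the measured compounds named here, compound 1 `CCC(C)(C)Cc1c[nH]c(CCc2ccc(-c3cccc(C)n3)cc2)n1` gives 6.3 nM in an in vitro assay on CHO cells for displacement of a labelled ligand from Bombesin receptor subtype-3 (Homo sapiens), read by scintillation counting, with a stated time of 2 h (on this read-out higher numbers stand for weaker inhibition and lower numbers for stronger inhibition), the lowest number of the three measured so far. Compound 2 `CCC(C)(C)Cc1c[nH]c(CCc2ccc(-c3ccncc3)cc2)n1` gives 101 nM, and compound 3 `CCC(C)(C)Cc1c[nH]c(CCc2ccc(-n3ncnn3)cc2)n1` gives 205 nM. Both departures from compound 1 at the aromatic carbon weaken binding: a 16-fold higher number from compound 1 to compound 2 (1.20 log units; beyond the scatter) and a 33-fold higher number from compound 1 to compound 3 (1.51 log units; beyond the scatter), with a further a 2.0-fold higher number from compound 2 to compound 3 (0.31 log units; beyond the scatter) between the two weaker compounds.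

Compound 4 `CCC(C)(C)Cc1c[nH]c(CCc2ccc(-n3ccnn3)cc2)n1` differs from compound 1 in one place: 1H-1,2,3-triazol-1-yl in place of 6-methylpyridin-2-yl on an aromatic carbon. The step of a 33-fold higher number from compound 1 to compound 3 (1.51 log units; beyond the scatter) bears most directly on this change, the 2H-tetrazol-2-yl of compound 3 being, like the entering group, a five-membered aromatic ring; the step of a 16-fold higher number from compound 1 to compound 2 (1.20 log units; beyond the scatter) shows that even a six-membered ring with one nitrogen in place of 6-methylpyridin-2-yl is costly. A large rise in this assay is therefore expected, probably falling between the two measured losses. Compound 4 is estimated at 150 nM, with a range of 50 nM to 450 nM, which corresponds to an expected 24-fold higher number from compound 1 to compound 4 (1.38 log units; beyond the scatter).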

Compound 4, half-maximal inhibitory concentration: 390 nM
For compound 4 the middle estimate is 2.6-fold (0.41 log units) below the measured one; measured number inside the range.
By their numbers in this assay, from the lowest: compound 1; then compound 2; then compounds 3 and 4 (each within the scatter of the next).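

In this assay, 1H-1,2,3-triazol-1-yl on this aromatic carbon, para to a large group, does not recover what is lost with 6-methylpyridin-2-yl (a 62-fold higher number from compound 1 to compound 4 (1.79 log units; beyond the scatter)), so the cost seen with the tetrazole extends to a second five-membered aromatic ring. The two azoles are not separated (a 1.9-fold higher number from compound 3 to compound 4 (0.28 log units; within the scatter)), and both stand apart from the six-membered pyridin-4-yl (a 3.9-fold higher number from compound 2 to compound 4 (0.59 log units; beyond the scatter)). No measurement at hand accounts for these differences.

Open, as far as these compounds go, is how plain pyridin-2-yl and 3-methylphenyl would read at this position, which would separate the contribution of the methyl from that of the ring nitrogen in compound 1. Also open, from the compounds shown here alone, is whether a methyl on the triazole ring of compound 4 would recover any binding.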